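Adding a methyl to the ring core of compound 2

A few compounds are considered here, and "the series" means these few. Any claim that something is new, unique, unknown or untested is made for them only; others in the source may bear on it.

Compound 1: `Cc1ccc2nc(-c3ccccc3Br)ccc2c1`, > 50000 nM
Compound 2: `Clc1ccc(-c2ccc3ccccc3n2)c(Cl)c1`, 25000 nM
Compound 3: `Nc1ccc(-c2ccc3ccc(Cl)cc3n2)cc1`, 6000 nM

Of the compounds shown here, three sharing one ring core have been tested in a functional assay on MCF7 cells (Homo sapiens) for cytotoxicity, read by MTT assay, with a stated time of 48 h; a higher number here means a weaker inhibitor, a lower number a stronger inhibitor. Compound 1 reaches only the assay limit, > 50000 nM, so its number is not known (the limit of > 50000 nM in this assay, at which 1 of the 3 values shown sits). Of the two real numbers, compound 2 holds the higher one, giving 25000 nM in this assay, while compound 3 gives 6000 nM; that gap lies beyond the usual scatter.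

Compound 4, `Cc1ccc2nc(-c3ccc(Cl)cc3Cl)ccc2c1`, has not yet been measured. Compared with compound 2 it carries one change: methyl in place of hydrogen on an aromatic carbon. Among the measured compounds shown here, no measured pair shows this change on its own, so no direct step is available. Compound 1, which carries the same methyl on the core but a different outer ring, sits at a limit, which gives no number to lean on.

The expectation is a small step, if any, from compound 2 to compound 4 in this assay, of about a 1.2-fold higher number from compound 2 to compound 4 (0.08 log units; within the scatter). Compound 4 is therefore estimated at 30000 nM, within a range from 10000 nM to 90000 nM.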

Compound 4, half-maximal inhibitory concentration: > 50000 nM
Compound 4: only a limit was reported; the forecaster's own chance of this, stated with the estimate: 30%; middle value at least 1.6-fold (0.22 log units) away from the limit.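

In this assay, among the compounds shown here, methyl in place of hydrogen on an aromatic carbon of the shared core can now be set against a real number for the first time, although the result is a limit of the assay and not a number. The change goes with an at least 2.0-fold higher number from compound 2 to compound 4 (0.30 log units; that floor lies within the scatter). At this position, then, the methyl brings no lower number, yet the floor alone does not show a real loss, and the top of the assay's range now restricts what can be read here: the limit of > 50000 nM in this assay, at which 2 of the 4 values shown sit.

From the compounds shown here alone, how far compound 4 truly lies from compound 2 stays open. So does whether a methoxy group or a carboxylic acid on that same aromatic carbon, in place of the methyl, would bring the number down.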